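The compounds below may be only part of what the source reports. "The series", "measured", "known", "first", "only" and "open" are said of these compounds alone.

Of the compounds shown here, three of a shared core have been tested in a functional assay on the whole organism for activation, with Mus musculus as the target; on this read-out higher numbers stand for an effect only at larger amounts of compound and lower numbers for an effect already at smaller amounts. Compound 1 `CSc1nc(N)c2nc(O)n(Cc3ccccc3)c2n1` carries a methylsulfanyl group on an aromatic carbon and gives 0.1 mg/kg. Compound 2 `CCCC[S+]([O-])c1nc(N)c2nc(O)n(Cc3ccccc3)c2n1` carries a larger sulfur-bearing group at the same place and gives 1 mg/kg. Compound 3 `Nc1nc(O)nc2c1nc(O)n2Cc1ccccc1` carries a hydroxy group there and gives 1 mg/kg, so compound 3 is level with compound 2 at the digits shown, and the two together stand at the highest numbers of the three, while compound 1 stands a full step lower, as the change a 10-fold higher number from compound 1 to compound 3 (1.00 log units; beyond the scatter) shows.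

Compound 4 `CCOc1nc(N)c2nc(O)n(Cc3ccccc3)c2n1` differs from compound 3 in one place: ethyl in place of hydrogen on an oxygen on an aromatic ring. Among the compounds with values here, no measured step describes an ethyl entering on this oxygen, so the expectation rests on what the neighbouring aromatic carbon tolerates. Replacing methylsulfanyl with hydroxy gave a 10-fold higher number from compound 1 to compound 3 (1.00 log units; beyond the scatter), and swapping the larger sulfur group for hydroxy gave no change at the digits printed from compound 2 to compound 3 (within the scatter). Covering the hydroxy with an ethyl thus moves compound 4 away from the weakest pattern seen, and a number between those of compound 1 and compound 3 is expected, meaning a step of a 3.3-fold lower number from compound 3 to compound 4 (0.52 log units; beyond the scatter). Compound 4 is therefore estimated at 0.3 mg/kg, within a range from 0.1 mg/kg to 1 mg/kg.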

Compound 4, minimum effective dose: 0.3 mg/kg
Estimate against measurement, compound 4: no gap at the digits printed; measured number inside the range.
By their numbers in this assay, from the lowest: compound 1; then compound 4; then compounds 2 and 3 (each within the scatter of the next).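

In this assay, putting ethyl on the oxygen gives a 3.3-fold lower number from compound 3 to compound 4 (0.52 log units; beyond the scatter) and so the hydroxy hydrogen can be replaced with a gain rather than a loss. Ethoxy also gives a 3.3-fold lower number from compound 2 to compound 4 (0.52 log units; beyond the scatter) when it takes the place of the larger sulfur-bearing group, whereas replacing methylsulfanyl with ethoxy gives a 3.0-fold higher number from compound 1 to compound 4 (0.48 log units; beyond the scatter) and leaves this group short of the mark set by compound 1, so this position now shows three separate levels rather than two. Group size alone does not set the order, as compound 2 and compound 3 carry the largest and the smallest of these groups yet print the same number.

Ethoxy and methylsulfanyl differ both in the atom attached to the aromatic carbon and in chain length, so methoxy and ethylsulfanyl would be needed to tell those two changes apart, and an amine or a longer chain such as butoxy would show how far the trend extends. Nothing measured here goes beyond the dose read-out, so these steps remain without an explanation.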